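Ethyl to allyl: from compound 2 to compound 4

A few compounds are considered here, and "the series" means these few. Any claim that something is new, unique, unknown or untested is made for them only; others in the source may bear on it.

In a functional assay on HeLa cells (Homo sapiens) for antiproliferative activity, read by sulforhodamine B assay (a higher number here means a weaker inhibitor of growth, a lower number a stronger inhibitor of growth), compound 1 (`CC[C@@H]1O[C@H](COCc2ccccc2)[C@@H](OCc2ccccc2)[C@H](OCc2ccccc2)[C@H]1O`) gives 19800 nM as its value. Compound 2 (`CC[C@@H]1O[C@H](COCc2ccccc2)[C@@H](OCc2ccccc2)[C@H](OCc2ccccc2)[C@H]1OC(C)=O`) gives > 50000 nM as a limit, not a number. Compound 3 (`CCCCCCCCCCCCCCCOC[C@H]1O[C@@H](CCC)[C@H](O)[C@@H](OCCCCCCCCCCCCCCC)[C@@H]1OCCCCCCCCCCCCCCC`) gives > 50000 nM as a limit too. Compound 2 therefore stands at the limit of > 50000 nM in this assay, at which 2 of the 3 values shown sit, with no number to count from. Compound 4 (`C=CC[C@@H]1O[C@H](COCc2ccccc2)[C@@H](OCc2ccccc2)[C@H](OCc2ccccc2)[C@H]1OC(C)=O`) differs from compound 2 by vinyl in place of methyl on a saturated chain carbon bound to a saturated ring carbon in the form of vinyl in place of methyl on a saturated chain carbon bound to a saturated ring carbon. Going by the values given here, the only measured step of an at least 2.5-fold higher number from compound 1 to compound 2 (0.40 log units; beyond the scatter) is acetyl in place of hydrogen, a different change, so it bears only indirectly. In this assay the expected step of a number no higher from compound 2 to compound 4 (the limit leaves the size open) is none beyond the scatter. For compound 4 the estimated value is 50000 nM with an expected range of 20000 nM to 100000 nM and a likely report as a limit.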

Compound 4, concentration for 50% growth inhibition: > 50000 nM
Compound 4: only a limit was reported; the forecaster's own chance of this, stated with the estimate: 70%; the middle value sits exactly at the limit.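

Going by these compounds alone, compound 2 and compound 4 are both reported only as limits in this assay, so no step between them can be read. Going by these compounds, whether ethyl and allyl differ in growth inhibition on this acetylated core remains open.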